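A few compounds are considered here, and "the series" means these few. Any claim that something is new, unique, unknown or untested is made for them only; others in the source may bear on it.

Measured compounds:
Compound 1 `COc1ccc2nccc(C3CN(C4CCN(Cc5cc6ccccc6[nH]5)C4)C(=O)O3)c2c1`. In an in vitro functional assay on RBL cells for antagonist activity at C-C chemokine receptor type 8 (Homo sapiens), read by FLIPR and calcium flux (a higher number here means a weaker inhibitor, a lower number a stronger inhibitor), compound 1 gives < 50200 nM, a limit of the assay rather than a number.
Compound 2 `COc1ccc2nccc(C3CN(C4CCCCN(Cc5cc6ccccc6[nH]5)C4)C(=O)O3)c2c1`. Compound 2 gives < 50200 nM, likewise a limit.
Compound 3 `COc1ccc2nccc(C3CN(C4CCN(Cc5ccc6ccccc6c5)CC4)C(=O)O3)c2c1`. Compound 3 gives 1260 nM.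

Within the data shown here, compound 3 therefore holds the only numerical value among the three; the other two sit at the limit of < 50200 nM in this assay, at which 2 of the 3 values shown sit, so no comparison of size between them and compound 3 can be made. Compound 4 `COc1ccc2nccc(C3CN(C4CCN(S(=O)(=O)c5ccc(Cl)c(Cl)c5)CC4)C(=O)O3)c2c1` has not yet been measured. It differs from compound 3 by (3,4-dichlorophenyl)sulfonyl in place of (naphthalen-2-yl)methyl on an amine nitrogen in a ring. Among the measured compounds shown here, no measured pair here isolates this change, so nothing in the data fixes its size. The value of compound 4 is estimated at 10000 nM, with a range from 2000 nM to 50000 nM. That estimate amounts to a step of a 7.9-fold higher number from compound 3 to compound 4 (0.90 log units; beyond the scatter), expected to run toward weaker inhibition and to lie beyond the usual scatter.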

Compound 4, half-maximal inhibitory concentration: < 50200 nM
Compound 4: a limit, no number (the forecaster's own chance of this, stated with the estimate: 40%); the middle value lies beyond the limit too.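

Among these compounds, compound 4 returns a limit rather than a number, so no step from compound 3 to compound 4 can be read: the limit of < 50200 nM in this assay, at which 3 of the 4 values shown sit. The compounds shown leave open how large the effect of exchanging (naphthalen-2-yl)methyl for (3,4-dichlorophenyl)sulfonyl is.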